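From a Fluoro to a Chloro on the Pendant Ring

The source may hold more compounds than are shown below. What is called first, only, known or untested is meant among the compounds shown, and "the series" means these compounds.

Measured compounds:
Compound 1, `c1ccc(-c2ccc(Cn3nnc4ccccc43)cc2)cc1`, in an ADME assay on microsomes from liver (Rattus norvegicus, strain Wistar) for metabolic stability, tested at 2.5 uM; on this read-out higher numbers stand for fast clearance and lower numbers for slow clearance: 12.6 mL/min/g
Compound 2, `Fc1ccc(-c2ccc(Cn3nnc4ccccc43)cc2)c(Cl)c1`, in this assay: 2.6 mL/min/g

Compound 2 stands lowest of the two numbers seen so far in this assay; its nearest neighbour is compound 1, which sits higher by a 4.8-fold lower number from compound 1 to compound 2 (0.69 log units; beyond the scatter). Compound 3, `Clc1ccc(-c2ccc(Cn3nnc4ccccc43)cc2)c(Cl)c1`, has not yet been measured in this assay. Its difference from compound 2 is chloro in place of fluoro on an aromatic carbon. Going by the values given here, the one measured step, a 4.8-fold lower number from compound 1 to compound 2 (0.69 log units; beyond the scatter), is the only guide; it covers the arrival of both halogens at once, so it bears on the new change only loosely. The exchange of one halogen for another is a smaller alteration than that step, so compound 3 is expected to sit close to compound 2, with a step of about a 1.2-fold lower number from compound 2 to compound 3 (0.07 log units; within the scatter) that may well fall within the scatter. Compound 3 is therefore estimated at 2.2 mL/min/g in this assay, within a range from 0.9 mL/min/g to 5.5 mL/min/g.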

Compound 3, intrinsic clearance in a liver preparation (reported as CLH), per the amount of preparation that the assay uses: 1.4 mL/min/g
Compound 3: the middle estimate sits 1.6-fold (0.20 log units) above what was measured; low and high end bracket the measured number.
By their numbers in this assay, from the lowest: compounds 3 and 2 (each within the scatter of the next); then compound 1.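

In this assay, chloro in place of fluoro on this aromatic carbon, meta to a chloro group and para to a large group, gives a 1.9-fold lower number from compound 2 to compound 3 (0.27 log units; within the scatter), so the two halogens cannot be told apart at this position. The earlier step covered the arrival of both halogens at once, and the new comparison shows that the drop from the phenyl of compound 1 holds with either halogen at this carbon: 2,4-dichlorophenyl in place of phenyl gives a 9.0-fold lower number from compound 1 to compound 3 (0.95 log units; beyond the scatter). No measurement here bears on what lies behind these numbers.

Open, from the compounds shown here alone, is whether a single chloro on the phenyl would do as much as the pair. Also open, going by these compounds, is whether methoxy, a nitrile or trifluoromethyl on this carbon would give numbers as low as those of compound 2 and compound 3.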